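The source may hold more compounds than are shown below. What is called first, only, known or untested is meant among the compounds shown, and "the series" means these compounds.

Working notes on the series. Compound 1 `CC(C)=CCC[C@]1(C)/C=C/[C@@H](OC(=O)C=C(C)C)[C@](C)(O)/C=C/C(=O)/C(CN(C(C)C)C(C)C)=C\C1` gives 650 nM in a functional assay on A549 cells (Homo sapiens) for antiproliferative activity, read by MTT assay, with a stated time of 48 h; a higher number here means a weaker inhibitor, a lower number a stronger inhibitor; compound 2 `CC(C)=CCC[C@]1(C)/C=C/[C@@H](OC(=O)C=C(C)C)[C@](C)(O)/C=C/C(=O)/C(CN2CCCC2)=C\C1` gives 180 nM; compound 3 `CC(C)=CCC[C@]1(C)/C=C/[C@@H](OC(=O)C=C(C)C)[C@](C)(O)/C=C/C(=O)/C(CN2CCN(C)CC2)=C\C1` gives 940 nM, the highest of the three numbers, set apart from compound 2 by a 5.2-fold higher number from compound 2 to compound 3 (0.72 log units; beyond the scatter) but not from compound 1, where a 1.4-fold higher number from compound 1 to compound 3 (0.16 log units; within the scatter) lies within the scatter. Compound 4 `CCN(CC)C(=O)/C1=C/C[C@](C)(CCC=C(C)C)/C=C/[C@@H](OC(=O)C=C(C)C)[C@](C)(O)/C=C/C1=O` differs from compound 3 in one place: diethylcarbamoyl in place of (4-methylpiperazin-1-yl)methyl on a double-bonded ring carbon. For the measured compounds named here, no measured step bears on this change; the steps seen so far, a 3.6-fold lower number from compound 1 to compound 2 (0.56 log units; beyond the scatter) and a 5.2-fold higher number from compound 2 to compound 3 (0.72 log units; beyond the scatter), only exchange one amine for another and give no guide to an amide in that place. The size of step is therefore uncertain, with a wide range in either direction. Compound 4 is estimated at 1500 nM (400 nM to 6000 nM), an expected step of a 1.6-fold higher number from compound 3 to compound 4 (0.20 log units; within the scatter).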

Compound 4, half-maximal inhibitory concentration: 11300 nM
Beside the measured number, compound 4's estimate is 7.5-fold (0.88 log units) below it; the whole stated range lies below it.
By their numbers in this assay, from the lowest: compound 2; then compounds 1 and 3 (each within the scatter of the next); then compound 4.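

At this double-bonded ring carbon, the change from an aminomethyl group to diethylcarbamoyl moves the number further than any exchange of one amine for another, in this assay: a 12-fold higher number from compound 3 to compound 4 (1.08 log units; beyond the scatter), a 17-fold higher number from compound 1 to compound 4 (1.24 log units; beyond the scatter) and a 63-fold higher number from compound 2 to compound 4 (1.80 log units; beyond the scatter). All three amines give lower numbers than the amide, so this place tolerates differences among these amines better than replacement by diethylcarbamoyl. No measurement available here accounts for the gap.

Going by these compounds, it stays open whether the carbonyl or the diethyl groups carry the step. Diethylaminomethyl or pyrrolidine-1-carbonyl in this place would separate the two.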